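Methoxy to hydroxy at one place in the series

A few compounds are considered here, and "the series" means these few. Any claim that something is new, unique, unknown or untested is made for them only; others in the source may bear on it.

Three compounds of the series have numbers in a functional assay on NCI-H322M cells (Homo sapiens) for cytotoxicity, read by sulforhodamine B assay, with a stated time of 48 h, tested at 10 uM; on this read-out higher numbers stand for a weaker effect at the one concentration tested and lower numbers for a stronger effect. Compound 1 `COc1cc(C)cc(-c2c(-c3ccnc(-c4ccc(N(C)C)cc4)c3)cnn2CC#N)c1` gives 21%, compound 2 `COc1cc(C)cc(-c2nn(CC#N)cc2-c2ccnc(-c3ccc(N(C)C)cc3)c2)c1` gives 27% and compound 3 `COc1cc(C)cc(-c2nn(CC#N)cc2-c2ccc(-c3cccc(C(C)=O)c3)nc2)c1` gives -10%. Compound 2 holds the highest of the three numbers; the number for compound 1 lies within the scatter of it, so nothing separates those two, while the number for compound 3 lies beyond the scatter and well below it. Among the measured compounds shown here, no single-point step between measured compounds is available, so no measured step can be read off as a guide.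

Compound 4 `Cc1cc(O)cc(-c2nn(CC#N)cc2-c2ccnc(-c3ccc(N(C)C)cc3)c2)c1` has not yet been measured. It differs from compound 2 in one place: hydrogen in place of methyl on an oxygen on an aromatic ring. The change is small in count, a hydrogen in place of a methyl on an oxygen on an aromatic ring, and the rest of the molecule is kept.

Given that no measured step informs it, the expected step from compound 2 to compound 4 in this assay is a number 2 percentage points lower from compound 2 to compound 4 (within the scatter), that is, no shift beyond the scatter in either direction. Compound 4 is therefore estimated at 25% in this assay, within a range from 0% to 50%.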

Compound 4, a percentage reported as activity, at one concentration (the size of the read-out at that concentration, not a potency): -11%
Compound 4: middle estimate off by 36 percentage points, on the high side; measured number outside the range, below it.
By their numbers in this assay, from the lowest: compounds 4 and 3 (each within the scatter of the next); then compounds 1 and 2 (each within the scatter of the next).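

In this assay the change from methoxy to hydroxy gives a number 38 percentage points lower from compound 2 to compound 4 (beyond the scatter) and so moves the read-out towards the stronger effect at the one concentration tested. The 3-methoxy-5-methylphenyl group therefore does not tolerate every small edit at this oxygen: hydrogen in place of one methyl on an oxygen on an aromatic ring is enough for a large step with the rest of the molecule kept. Among the compounds shown here, the earlier compounds offered no single-point step, so this pair is the first direct sign that this position matters, and it remains a single pair. Nothing shown accounts for the size or direction of this step.

The compounds shown leave open whether the step follows from the hydroxy group itself or from the loss of the methyl, a question that an ethoxy group, an amine or a fluorine at the same place would help to separate. They also leave open whether the same methoxy to hydroxy change gives a comparable step on the frameworks of compound 1 and compound 3.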